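Removing the 4-methylpiperazinyl group from the benzamide of compound 1

The source may hold more compounds than are shown below. What is called first, only, known or untested is meant among the compounds shown, and "the series" means these compounds.

Compound 1 `COc1cc(OC)c(Cl)c(-c2ccc3c(NC(=O)c4ccc(N5CCN(C)CC5)cc4)n[nH]c3n2)c1Cl` carries a 4-methylpiperazin-1-yl group on the benzamide ring. Going by the values given here, in a functional assay on NCI-H1581 cells (Homo sapiens) for antiproliferative activity, read by CCK-8 assay, with a stated time of 72 h (on this read-out higher numbers stand for weaker inhibition and lower numbers for stronger inhibition), compound 1 gives 1.7 nM, the lowest of the two numbers so far. Its nearest neighbour, compound 2 `COc1cc(OC)c(Cl)c(-c2ccc3c(NC(=O)c4ccc(N5CCN(C)CC5)cc4)n[nH]c3c2)c1Cl`, is a core isomer of compound 1 and in this assay compound 2 gives 324 nM, a gap that lies well beyond the scatter of the method. Among the compounds with values here, no pair differing in a single place has yet been measured, so there is no calibrated step on which to rest the next prediction.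

Compound 3 `COc1cc(OC)c(Cl)c(-c2ccc3c(NC(=O)c4ccccc4)n[nH]c3n2)c1Cl` is the analogue in which the 4-methylpiperazin-1-yl group of compound 1 is taken away: hydrogen in place of 4-methylpiperazin-1-yl on an aromatic carbon. Within the data shown here, nothing among the measured compounds tells what this particular removal costs. In the absence of any such step the change is expected to weaken inhibition only modestly, a step from compound 1 to compound 3 of about a 4.7-fold higher number from compound 1 to compound 3 (0.67 log units; beyond the scatter) in this assay. Compound 3 is therefore estimated to give 8 nM in this assay, within a range of 2 nM to 40 nM.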

Compound 3, half-maximal inhibitory concentration: > 1000 nM
Compound 3: a limit, no number; the forecaster's own chance of this, stated with the estimate: 2%; middle value at least 120-fold (2.09 log units) from the limit.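

This gives the series its first calibrated step: in this assay, hydrogen in place of 4-methylpiperazin-1-yl on an aromatic carbon gives an at least 580-fold higher number from compound 1 to compound 3 (2.76 log units; beyond the scatter), so the low number of compound 1 depends heavily on what stands at this place on the benzamide ring. The reading for compound 3 is a limit of the assay and not a number: the limit of > 1000 nM in this assay, at which 1 of the 3 values shown sits.

The shared core with an unsubstituted benzamide, as in compound 3, therefore does not by itself carry the low number of compound 1 in this assay.

Going by these compounds, it remains open which part of the 4-methylpiperazin-1-yl group matters, and whether a piperazine without the methyl, a morpholine ring, a simple dimethylamino group or a carboxylic acid at this place would restore the low number. On these data alone, it also remains open whether removing the group would cost as much on the core of compound 2, where the starting number is already much higher.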